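A few compounds are considered here, and "the series" means these few. Any claim that something is new, unique, unknown or untested is made for them only; others in the source may bear on it.

The measured compounds:
compound 1 `O=C(CCCCCCc1ccccc1)c1ncc(-c2ccc(CCl)cn2)o1` with 24 nM in an assay for inhibition of Fatty-acid amide hydrolase 1 (Rattus norvegicus), using a Dixon plot, with a stated time of 1 h; a higher number here means a weaker inhibitor, a lower number a stronger inhibitor
compound 2 `CCOS(=O)(=O)/C=C/c1ccc(-c2cnc(C(=O)CCCCCCc3ccccc3)o2)nc1` with 0.3 nM in this assay

Compound 1 stands at the higher of the two numbers; its nearest neighbour is compound 2, reached by the step of an 80-fold lower number from compound 1 to compound 2 (1.90 log units; beyond the scatter). Compound 3 `CSC(=O)CCCCc1cnc(C(=O)CCCCCCc2ccccc2)o1` is not yet measured. It differs from compound 1 in that (a group of 8 heavy atoms (6 carbon, 1 oxygen, 1 sulfur; no ring) in place of a group of 8 heavy atoms (6 carbon, 1 nitrogen, 1 chlorine; one six-membered aromatic ring with 1 hetero atom), on an aromatic carbon). Among the measured compounds shown here, the one measured step, an 80-fold lower number from compound 1 to compound 2 (1.90 log units; beyond the scatter), exchanged a group on the six-membered ring while that ring stayed; here the ring itself leaves and a chain enters. For the measured compounds named here, that step shows only that changes at this place can move the number a great deal, not in which direction this one will, and no measured step resembles the present change directly. The expected step is a 2.5-fold higher number from compound 1 to compound 3 (0.40 log units; beyond the scatter), toward a weaker inhibitor, with wide uncertainty. Compound 3 is therefore estimated at 60 nM in this assay, between 10 nM and 400 nM.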

Compound 3, inhibition constant: 1.7 nM
Compound 3: the middle estimate sits 35-fold (1.55 log units) above what was measured; measured number outside the range, below it.
By their numbers in this assay, from the lowest: compound 2; then compound 3; then compound 1.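

In this assay the whole six-membered aromatic ring on the aromatic carbon next to the ring oxygen gives way to a group with no ring, and the outcome is a 14-fold lower number from compound 1 to compound 3 (1.15 log units; beyond the scatter) toward a stronger inhibitor. The earlier pair showed only a swap on that ring while the ring stayed, whereas this pair shows that a low number at this position does not depend on having the ring at all. Nothing measured here explains why the number falls.

Going by these compounds, it remains open which part of the new group matters, the sulfur, the double bond outside aromatic rings or simply the length of the chain. A carboxylic acid or an amide at the end of the chain, or a shorter or longer chain, could begin to separate these.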